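The compounds below may be only part of what the source reports. "The series", "measured", "known", "first", "only" and "open" are said of these compounds alone.

Measured so far in an assay on isolated protein for inhibition of lysosomal alpha-glucosidase (Rattus norvegicus), tested at 100 uM; a higher number here means more inhibition at the concentration tested (going by the name of the read-out), a lower number less inhibition:
- compound 1, `CCOC(=O)C(C(=O)OCC)C(CC(=O)C[C@@H]1O[C@H](CO)[C@@H](O)[C@H](O)[C@H]1O)c1ccc(Cl)cc1`: -10%
- compound 2, `O=C(/C=C/c1ccc(Cl)cc1)C[C@@H]1OC[C@@H](O)[C@H](O)[C@H]1O`: -8.3%

Both numbers sit at or slightly under zero, so neither compound shows inhibition at the concentration tested. Compound 1 holds the bottom of the two numbers, yet its gap to compound 2 lies within the scatter, so the two cannot be told apart on this assay. Going by the values given here, no step between measured compounds that differ in one place is available, and compound 2 differs from compound 1 in more than one place, so its value gives no guide to any single change.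

The next compound, compound 3, `CCOC(=O)C(C(=O)OCC)C(CC(=O)C[C@@H]1O[C@H](CO)[C@@H](O)[C@H](O)[C@H]1O)c1cccnc1`, is compound 1 with one change: pyridin-3-yl in place of 4-chlorophenyl on a saturated chain carbon bound to two saturated chain carbons. The rest of the molecule, the core and both ester chains, is unchanged. Among the compounds with values here, with both measured compounds at baseline and no step to rest on, nothing points to a move beyond the scatter in this assay in either direction; the step from compound 1 is expected to be a number 5 percentage points higher from compound 1 to compound 3 (within the scatter), that is, none beyond the scatter. Compound 3 is therefore estimated at -5%, within a range of -20% to 12%.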

Compound 3, a percentage reported as inhibition, at one concentration (the size of the read-out at that concentration, not a potency): -20%
Estimate against measurement, compound 3: 15 percentage points above; low and high end bracket the measured number.
By their numbers in this assay, from the lowest: compounds 3, 1 and 2 (each within the scatter of the next, the first and the last beyond it).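

Going by these compounds alone, this is the first step that can be read at a single place: pyridin-3-yl in place of 4-chlorophenyl, on a saturated chain carbon bound to two saturated chain carbons, gives a number 10 percentage points lower from compound 1 to compound 3 (within the scatter) in this assay. The exchange of a carbon-only aromatic ring bearing chlorine for an aromatic ring with one hetero atom and one hydrogen-bond acceptor therefore does not bring out inhibition at the concentration tested, and compound 3, at -20%, stays under zero. No independent measurement bears on this result.

On these data alone, whether any group at this position can lift the number clear of baseline remains open, since the two aromatic rings compared here leave the read-out without measurable inhibition and so give no direction for further change. As far as these compounds go, a carboxylic acid in place of the two ethyl esters, or an aminomethyl group on the aromatic ring, would test whether the shared core can show inhibition in this assay at all, and a shorter chain between the core and the ring remains equally open.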